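Trifluoromethoxy in Place of Dimethylamino on the Shared Core

The compounds below may be only part of what the source reports. "The series", "measured", "known", "first", "only" and "open" are said of these compounds alone.

Of the compounds shown here, three sharing one core have been measured in an assay for inhibition of cytochrome P450 1A1 (Homo sapiens), read by fluorescence, using microsomes, with a stated time of 10 min; a lower number here means a stronger inhibitor, a higher number a weaker inhibitor. Compound 1 `COc1cccc(/C=C/C(=O)c2ccc[nH]2)c1OC` gives 5200 nM in this assay. Compound 2 `O=C(/C=C/c1ccc(Br)cc1)c1ccc[nH]1` reaches only the limit of the assay, > 20000 nM. Compound 3 `CN(C)c1ccc(/C=C/C(=O)c2ccc[nH]2)cc1` likewise reaches only the limit, > 20000 nM, and so stands as a limit rather than a number among the values shown. The step that the two limits leave unreadable from compound 2 to compound 3 therefore cannot be read, since (the limit of > 20000 nM in this assay, at which 2 of the 3 values shown sit). Compound 4 `O=C(/C=C/c1ccc(OC(F)(F)F)cc1)c1ccc[nH]1` differs from compound 3 in one place: trifluoromethoxy in place of dimethylamino on an aromatic carbon. For the measured compounds named here, no measured step bears directly on this exchange, and the values of compound 2 and compound 3 give no size to work from. Compound 4 is therefore expected to remain weak, with an estimated step of a number no higher from compound 3 to compound 4 (the limit leaves the size open) that rests on no measured number. The estimate for compound 4 is 20000 nM, ranging from 6000 nM to 60000 nM.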

Compound 4, half-maximal inhibitory concentration: > 20000 nM
Compound 4 ended at the assay's limit; the forecaster's own chance of this, stated with the estimate: 60%; the middle value sits exactly at the limit.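

Compound 4 also stands only at a limit (> 20000 nM), so its steps from compound 2 and compound 3 cannot be read: (the limit of > 20000 nM in this assay, at which 3 of the 4 values shown sit). On these data alone, how far these three compounds differ from one another in this assay stays open.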